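A few compounds are considered here, and "the series" means these few. Any claim that something is new, unique, unknown or untested is made for them only; others in the source may bear on it.

In a functional assay on U-937 cells (Homo sapiens) for antiproliferative activity, read by MTT assay, with a stated time of 24 h (a higher number here means a weaker inhibitor, a lower number a stronger inhibitor), compound 1 `CCCCc1oc2ccccc2c1C(=O)c1ccc(OCCCC(=O)N2CCCC2)cc1` gives 7500 nM, compound 2 `CCCCc1oc2ccccc2c1C(=O)c1ccc(OCCCC(=O)N2CCCCC2)cc1` gives 16600 nM and compound 3 `CCCCc1oc2ccccc2c1C(=O)c1ccc(OCCCC(=O)NCc2ccccc2)cc1` gives 15800 nM. Compound 3 therefore sits level with compound 2, as the step of a 1.1-fold lower number from compound 2 to compound 3 (0.02 log units; within the scatter) stays within the scatter, and apart from compound 1, as shown by the step of a 2.1-fold higher number from compound 1 to compound 3 (0.32 log units; beyond the scatter).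

Compound 4 `CCCCc1oc2ccccc2c1C(=O)c1ccc(OCCCC(=O)N[C@H](C)c2ccccc2)cc1` differs from compound 3 at one place: methyl in place of hydrogen on a saturated chain carbon bound to an amide-type nitrogen and an aromatic carbon. This is methyl in place of hydrogen on a saturated chain carbon bound to an amide-type nitrogen and an aromatic carbon, so benzylamino becomes (1-phenylethyl)amino.

For the measured compounds named here, no measured step makes this exact change. The closest evidence is the swaps of the group on the carbonyl carbon: the modest 2.2-fold higher number from compound 1 to compound 2 (0.35 log units; beyond the scatter), the equally modest a 2.1-fold higher number from compound 1 to compound 3 (0.32 log units; beyond the scatter), and a 1.1-fold lower number from compound 2 to compound 3 (0.02 log units; within the scatter), which lies within the scatter. Among these three compounds, even whole-group swaps move this assay only modestly, so no step beyond the scatter is expected from a single added methyl, and no direction can be favoured with confidence.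

The expected step is a 1.1-fold lower number from compound 3 to compound 4 (0.05 log units; within the scatter). For compound 4 the estimated value is 14000 nM, with a range of 7000 nM to 28000 nM.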

Compound 4, half-maximal inhibitory concentration: 30700 nM
The estimate for compound 4 lay 2.2-fold (0.34 log units) below the measured number; measured number above the stated range.
By their numbers in this assay, from the lowest: compound 1; then compounds 3, 2 and 4 (each within the scatter of the next).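

In this assay methyl in place of hydrogen on the saturated chain carbon bound to an amide-type nitrogen and an aromatic carbon gives a 1.9-fold higher number from compound 3 to compound 4 (0.29 log units; within the scatter) and so shows that this position tolerates the added methyl without a step beyond the scatter. For the compounds shown here, the (1-phenylethyl)amino group likewise stays level with the piperidin-1-yl group, with a 1.8-fold higher number from compound 2 to compound 4 (0.27 log units; within the scatter) as the step, whereas the comparison with the pyrrolidin-1-yl group gives a 4.1-fold higher number from compound 1 to compound 4 (0.61 log units; beyond the scatter) as a modest step and the widest gap so far. No measured evidence bears on the reason for these steps.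

The compounds shown leave open how the mirror-image (1-phenylethyl)amino amide would read in this assay. They also leave open whether an ethyl or a hydroxymethyl group on the same carbon would stay level with compound 3.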